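The source may report more compounds than this note shows. Statements on the series, on what has been measured and on what is new or still open speak of the compounds shown alone.

Measured so far:
- compound 1 `Cc1ccc2nc(/N=C3\C(=O)N(CN4CCCCC4)c4ccccc43)sc2c1`: 37800 nM
- compound 2 `Cc1ccc2nc(/N=C3\C(=O)N(CN4CCCCC4)c4cccc(Br)c43)sc2c1`: 39100 nM
- compound 3 `Cc1ccc2nc(/N=C3\C(=O)N(CN(C)C)c4cccc(Cl)c43)sc2c1`: 20700 nM

In a functional assay on MCF7 cells (Homo sapiens) for cytotoxicity, read by sulforhodamine B assay, with a stated time of 48 h (a lower number here means a stronger inhibitor of growth, a higher number a weaker inhibitor of growth), compound 3 gives the lowest of the three numbers, yet its gaps to compound 1 and to compound 2 both stay within the usual scatter, so no order among them can be read. Compound 4 `Cc1ccc2nc(/N=C3\C(=O)N(CN4CCCCC4)c4cccc(Cl)c43)sc2c1` arises from compound 3 by piperidin-1-yl in place of dimethylamino on a saturated chain carbon bound to an amide-type nitrogen in a ring. For the measured compounds named here, no measured pair isolates this exchange. Going by the values given here, the one single-point step available, a 1.0-fold higher number from compound 1 to compound 2 (0.01 log units; within the scatter), shows that swapping a ring substituent changed little. Compound 2 already carries the piperidin-1-yl group beside a bromo group and gives 39100 nM, which sits close to compound 1. The expected step of a 1.4-fold higher number from compound 3 to compound 4 (0.16 log units; within the scatter) is therefore small. Compound 4 is estimated at 30000 nM, within 12000 nM to 75000 nM.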

Compound 4, concentration for 50% growth inhibition: 30900 nM
For compound 4 the middle estimate is 1.0-fold (0.01 log units) below the measured one; low and high end bracket the measured number.
By their numbers in this assay, from the lowest: compounds 3, 4, 1 and 2 (each within the scatter of the next).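

In this assay, the exchange of dimethylamino for piperidin-1-yl on a saturated chain carbon bound to an amide-type nitrogen in a ring can now be read directly: a 1.5-fold higher number from compound 3 to compound 4 (0.17 log units; within the scatter), so the two groups cannot be told apart here. On the aromatic carbon, chloro likewise cannot be told from bromo, a 1.3-fold lower number from compound 2 to compound 4 (0.10 log units; within the scatter), or from hydrogen, a 1.2-fold lower number from compound 1 to compound 4 (0.09 log units; within the scatter). No outside measurement is available to explain these results. From the compounds shown here alone, whether morpholin-4-yl on that chain carbon, or methoxy on the aromatic carbon, would give a step beyond the scatter stays open.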